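Replacing the 4-Methoxyphenyl Arm with tert-Butyl

The compounds below may be only part of what the source reports. "The series", "measured", "known", "first", "only" and "open" are said of these compounds alone.

Compound 2 `COc1ccc(-c2nn(-c3ccccc3)c(/N=C/N(C)C)c2C=O)cc1` gives 27200 nM in a functional assay on NPC-TW01 cells (Homo sapiens) for inhibition, read by MTT assay, with a stated time of 72 h (on this read-out higher numbers stand for weaker inhibition of growth and lower numbers for stronger inhibition of growth), the highest of the two numbers in hand. Within the data shown here, its only neighbour, compound 1 `CN(C)/C=N/c1c(C=O)c(-c2ccccc2)nn1-c1ccccc1`, gives 9300 nM in this assay. Among the measured compounds shown here, the single measured step, a 2.9-fold higher number from compound 1 to compound 2 (0.47 log units; beyond the scatter), concerns the methoxy group on the phenyl arm alone. Compound 3 `CN(C)/C=N/c1c(C=O)c(C(C)(C)C)nn1-c1ccccc1` goes further: tert-butyl in place of 4-methoxyphenyl on an aromatic carbon. For the measured compounds named here, no measured pair shows the loss of the whole aryl arm, so that step bears on the change only in part. A modest fall in number is expected for compound 3 because a 2.9-fold higher number from compound 1 to compound 2 (0.47 log units; beyond the scatter) shows that the methoxy group adds to the number, and compound 3 lacks that group. Whether the tert-butyl group itself raises or lowers the number beyond that, the data do not show, so the uncertainty is wide. The expected step, a 2.3-fold lower number from compound 2 to compound 3 (0.36 log units; beyond the scatter), is therefore moderate. Compound 3 is estimated at 12000 nM in this assay, with a range from 3500 nM to 45000 nM.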

Compound 3, concentration for 50% growth inhibition: > 50000 nM
Compound 3 gave a limit, no number; the forecaster's own chance of this, stated with the estimate: 10%; middle value at least 4.1-fold (0.61 log units) from the limit.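

Among these compounds, compound 3 stops at a limit of the assay and gives no number in this assay, and that limit is the only reading available for it: the limit of > 50000 nM in this assay, at which 1 of the 3 values shown sits.

Set against the unsubstituted phenyl arm, the step is clear: an at least 5.3-fold higher number from compound 1 to compound 3 (0.73 log units; beyond the scatter) shows that tert-butyl in place of phenyl on this aromatic carbon, next to the ring atom that bears a formyl group, weakens growth inhibition, which the methoxy step alone could not show, since there the aromatic arm stayed in place. Set against the 4-methoxyphenyl arm, the reading is less firm, as an at least 1.8-fold higher number from compound 2 to compound 3 (0.26 log units; that floor lies within the scatter) has a floor that does not by itself separate the two compounds, so only the comparison with the phenyl arm shows a loss at this position.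

The compounds shown leave open whether that loss follows the aromatic ring itself, as a cyclohexyl ring or a methyl group at this carbon would help to tell. They also leave open how a hydroxyl group or an amine in place of methoxy on the phenyl arm would read, and how far past its limit compound 3 lies.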